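The source may report more compounds than this note shows. Statements on the series, on what has been measured and on what is new or still open speak of the compounds shown alone.

All three measured compounds were tested in a functional assay on the whole organism (strain Swiss) with Mus musculus as the target, in the maximal electroshock model, with a stated time of 2 h, at a dose of 100 mg/kg by the intraperitoneal route; on this read-out lower numbers stand for a weaker effect and higher numbers for a stronger effect at the one dose given:

Compound 1, `CC(C(=O)N1CCN(c2ccccc2)CC1)N1C(=O)CCC1=O`, gave 0%.
Compound 2, `CC(C(=O)N1CCN(c2ccccc2F)CC1)N1C(=O)CCC1=O`, gave 0%.
Compound 3, `CCC(C(=O)N1CCN(c2ccccc2F)CC1)N1C(=O)CCC1=O`, gave 0%.

Compound 3 stands level with compounds 1 and 2 on the numbers measured. The two steps joining them were flat: no change at the digits printed from compound 1 to compound 2 (within the scatter), and no change at the digits printed from compound 2 to compound 3 (within the scatter). Neither the fluoro on the aromatic ring nor the methyl on the chain carbon moved the read-out beyond the scatter.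

Compound 4, `CCC(C(=O)N1CCN(c2cccc(Cl)c2)CC1)N1C(=O)CCC1=O`, is reached from compound 3 by one change: 3-chlorophenyl in place of 2-fluorophenyl on an amine nitrogen in a ring. Within the data shown here, of the measured steps, only the one from compound 1 to compound 2 touches the same aryl ring, and it was a non-event, no change at the digits printed from compound 1 to compound 2 (within the scatter). Nothing in the series has so far moved this assay. No step beyond the scatter is therefore expected for no change at the digits printed from compound 3 to compound 4 (within the scatter). Compound 4 is estimated at 0%, within 0% to 20%.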

Compound 4, a percentage reported as activity, at one dose (the size of the read-out at that dose, not a potency): 0%
Compound 4: the middle estimate sits on the measured number at the digits printed; the range from low to high includes it.
By their numbers in this assay, from the lowest: compounds 1, 2, 3 and 4 (each within the scatter of the next).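

In this assay, the swap of 2-fluorophenyl for 3-chlorophenyl on the amine nitrogen in a ring gave no change at the digits printed from compound 3 to compound 4 (within the scatter), so a change of both the halogen and its place on the aryl ring left the read-out as flat as the earlier fluoro for hydrogen step did. Among these compounds, this position has now carried phenyl, 2-fluorophenyl and 3-chlorophenyl with no reading that separates them, and since compound 4 gives 0% like the others, the series offers no active compound to compare against. Nothing measured here accounts for this flat read-out.

Still open, on these data alone, is whether a trifluoromethyl or methoxy group on the aryl ring, or a benzyl group in place of the aryl ring, would lift the read-out at this position. The compounds shown also leave open whether a longer chain on the carbon bearing the methyl would do so.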